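Replacing a phenylethyl with a fluorophenyl on the ring amine

The compounds below may be only part of what the source reports. "The series", "measured", "known", "first", "only" and "open" are said of these compounds alone.

Compound 1 `CCCn1c(=O)[nH]c2nc(-c3ccc(S(=O)(=O)N4CCN(c5cccc(Br)c5)CC4)cc3)[nH]c2c1=O` gives 0.234 nM in an assay on CHO cells for displacement of a labelled ligand from adenosine receptor A2b (Homo sapiens), read by scintillation counting, with a stated time of 75 min, in the presence of a further agent that is not named here; on this read-out lower numbers stand for stronger inhibition and higher numbers for weaker inhibition.
Compound 2 `CCCn1c(=O)[nH]c2nc(-c3ccc(S(=O)(=O)N4CCN(c5cccc(Cl)c5)CC4)cc3)[nH]c2c1=O` gives 0.342 nM in this assay.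
Compound 3 `CCCn1c(=O)[nH]c2nc(-c3ccc(S(=O)(=O)N4CCN(C(C)c5ccccc5)CC4)cc3)[nH]c2c1=O` gives 8.34 nM in this assay.

Compound 3 stands at the highest number of the three, and its distance from the other two is clear: a 36-fold higher number from compound 1 to compound 3 (1.55 log units; beyond the scatter) and a 24-fold higher number from compound 2 to compound 3 (1.39 log units; beyond the scatter), both beyond the scatter, whereas a 1.5-fold higher number from compound 1 to compound 2 (0.16 log units; within the scatter). Compound 4 `CCCn1c(=O)[nH]c2nc(-c3ccc(S(=O)(=O)N4CCN(c5ccccc5F)CC4)cc3)[nH]c2c1=O` has not yet been measured in this assay. It differs from compound 3 in one place: 2-fluorophenyl in place of 1-phenylethyl on an amine nitrogen in a ring. The two large steps from compound 1 and from compound 2 to compound 3 bear on this change, since in both of those compounds the amine nitrogen in the ring carries an aromatic ring directly, as it does in compound 4, and both steps run the other way. Among the compounds with values here, a step back toward lower numbers, of comparable size, is therefore expected for compound 4, with uncertainty because no measured compound carries the 2-fluorophenyl group. Compound 4 is estimated at 0.6 nM, within 0.15 nM to 3 nM, which means an expected step of a 14-fold lower number from compound 3 to compound 4 (1.14 log units; beyond the scatter).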

Compound 4, inhibition constant: 3.22 nM
For compound 4 the middle estimate is 5.4-fold (0.73 log units) below the measured one, outside the stated range (above it).
By their numbers in this assay, from the lowest: compounds 1 and 2 (each within the scatter of the next); then compound 4; then compound 3.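

In this assay, moving from 1-phenylethyl to a ring attached directly to the amine nitrogen gives only a 2.6-fold lower number from compound 3 to compound 4 (0.41 log units; beyond the scatter), so direct attachment of an aromatic ring does not by itself reach the numbers of compounds 1 and 2. The substituted phenyl group matters as well: the listed steps are a 9.4-fold higher number from compound 2 to compound 4 (0.97 log units; beyond the scatter) and a 14-fold higher number from compound 1 to compound 4 (1.14 log units; beyond the scatter), whereas bromo and chloro had remained within the scatter of each other. No evidence is available to explain these differences.

Because 2-fluorophenyl differs from 3-chlorophenyl and 3-bromophenyl in both the halogen and the number in its name, the compounds shown cannot separate those two changes. From the compounds shown here alone, a 3-fluorophenyl or an unsubstituted phenyl group on the same nitrogen would address what remains open.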